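The source may hold more compounds than are shown below. What is called first, only, known or untested is meant among the compounds shown, and "the series" means these compounds.

Working notes on the series, read throughout in a functional assay on HL-60 cells (Homo sapiens) for antiproliferative activity, read by MTT assay, with a stated time of 72 h (on this read-out higher numbers stand for weaker inhibition and lower numbers for stronger inhibition), as the single test. In this assay compound 1 (`COc1cc(-c2ncnn2-c2ccc(Cl)cc2Cl)cc(OC)c1OC`) gives > 10000 nM as its reading, and this is a limit, not a number. Compound 2 (`COc1cccc(-c2ncnn2-c2cc(OC)c(OC)c(OC)c2)c1`) gives > 10000 nM as its reading, again a limit. Compound 3 (`CCOc1cccc(-c2ncnn2-c2cc(OC)c(OC)c(OC)c2)c1`) gives > 10000 nM as its reading, also a limit. No order can be read among these three, and compound 1 has no measured distance from the others: the limit of > 10000 nM in this assay, at which 3 of the 3 values shown sit, describes the whole set so far.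

The next entry is compound 4 (`COc1cc(-c2ncnn2-c2ccccc2)cc(OC)c1OC`), which carries phenyl in place of 2,4-dichlorophenyl on an aromatic nitrogen of the core of compound 1. The counted difference is phenyl in place of 2,4-dichlorophenyl on an aromatic nitrogen and nothing else changes.

Going by the values given here, the only measured step is a step that the two limits leave unreadable from compound 2 to compound 3 and it lies at a different place, so it gives no size to carry over to this change. With no number anywhere in the series, the expectation is no step beyond the scatter, and no direction can be called: the estimated step is a step that the limit leaves unreadable from compound 1 to compound 4 on this reading. For compound 4 the expected value is about 12000 nM with an estimated range of 3000 nM to 40000 nM and a further reading at the limit is the likeliest outcome.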

Compound 4, half-maximal inhibitory concentration: > 10000 nM
Compound 4: only a limit was reported; the forecaster's own chance of this, stated with the estimate: 80%; the middle value does not contradict the limit.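

No new step can be read: compound 1 and compound 4 both give only a limit, and phenyl in place of 2,4-dichlorophenyl on an aromatic nitrogen has no readable size or direction. The compounds shown leave open which change, if any, would bring a reading to a measured number, with the whole set still at one limit: the limit of > 10000 nM in this assay, at which 4 of the 4 values shown sit.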